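Swapping an aminophenyl for an aminopyridinyl on the shared core

The compounds below may be only part of what the source reports. "The series", "measured", "known", "first", "only" and "open" are said of these compounds alone.

Three compounds share a core, and compound 1 `Cc1ncc([N+](=O)[O-])n1CCSc1nnc(-c2ccccc2N)o1` sits at the weak end of the set. In a functional assay on SGC-7901 cells (Homo sapiens) for cytotoxicity, read by MTT assay, with a stated time of 48 h (on this read-out higher numbers stand for weaker inhibition and lower numbers for stronger inhibition), compound 1 gives 35100 nM, the highest of the three numbers. Compound 2 `COc1ccc(-c2nnc(SCCn3c([N+](=O)[O-])cnc3C)o2)c(O)c1` gives 11700 nM in this assay, and compound 3 `COc1cc(OC)cc(-c2nnc(SCCn3c([N+](=O)[O-])cnc3C)o2)c1` gives 9600 nM; both gaps to compound 1 lie beyond the usual scatter, so compound 1 is the weakest of the three on this read-out. Among the compounds with values here, no pair of measured compounds differs in just one place, so no single-change step is available to anchor a forecast.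

The unmeasured compound 4 `Cc1ncc([N+](=O)[O-])n1CCSc1nnc(-c2cnccc2N)o1` differs from compound 1 in one place: 4-aminopyridin-3-yl in place of 2-aminophenyl on an aromatic carbon. With no comparable change among the measured compounds, nothing shows whether exchanging one six-membered aromatic ring of carbon only for one with 1 hetero atom moves the number at all. The step from compound 1 to compound 4 is therefore expected to be small, within the scatter, with no firm direction. Accordingly compound 4 is expected at 30000 nM, within a range from 12000 nM to 80000 nM, which corresponds to an expected step of a 1.2-fold lower number from compound 1 to compound 4 (0.07 log units; within the scatter).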

Compound 4, half-maximal inhibitory concentration: 34500 nM
Beside the measured number, compound 4's estimate is 1.2-fold (0.06 log units) below it; low and high end bracket the measured number.
By their numbers in this assay, from the lowest: compounds 3 and 2 (each within the scatter of the next); then compounds 4 and 1 (each within the scatter of the next).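

Within the data shown here, exchanging 2-aminophenyl for 4-aminopyridin-3-yl on this aromatic carbon of the shared core gives, in this assay, a 1.0-fold lower number from compound 1 to compound 4 (0.01 log units; within the scatter), and this is the only single-change step in the set. Among these compounds, it shows that, at this position, a six-membered aromatic ring of carbon only can give way to one with 1 hetero atom without any change that can be told from the scatter, something the earlier compounds, none of them a single change apart, could not show. No measurement at hand explains why the number holds here.

Among the compounds shown here, the single step leaves open whether the amine on this ring matters to the number at all, which an unsubstituted phenyl or pyridinyl ring, or an acetamide or a dimethylamino group in its place, would address. It also leaves open whether a second ring nitrogen, as in a pyrimidine ring, would leave the number as unmoved, and whether the same exchange would do so on rings carrying other groups, such as a fluorine or a carboxylic acid.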